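The compounds below may be only part of what the source reports. "The series", "measured", "known", "first", "only" and "open" are said of these compounds alone.

Compound 2 `COc1ccc(-c2[nH]c3ccc(OC)cc3c2/C=C(\C#N)S(=O)(=O)c2ccccc2)cc1` is one of two analogues measured so far. In a functional assay on SK-MEL-5 cells (Homo sapiens) for inhibition, read by sulforhodamine B assay, with a stated time of 48 h (a lower number here means a stronger inhibitor of growth, a higher number a weaker inhibitor of growth), compound 2 gives 319 nM, and compound 1 `COc1ccc(-c2[nH]c3ccccc3c2/C=C(\C#N)S(=O)(=O)c2ccccc2)cc1` gives 344 nM. Of these two numbers compound 2 has the lower one, but the step of a 1.1-fold lower number from compound 1 to compound 2 (0.03 log units; within the scatter) is within the scatter, so the two compounds cannot be told apart on this read-out.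

Compound 3 `COc1ccc2[nH]c(-c3ccccc3)c(/C=C(\C#N)S(=O)(=O)c3ccccc3)c2c1` is not yet measured. It differs from compound 2 by hydrogen in place of methoxy on an aromatic carbon. For the measured compounds named here, the only measured step, methoxy entering on an aromatic carbon elsewhere on the shared core, was a 1.1-fold lower number from compound 1 to compound 2 (0.03 log units; within the scatter), which bears on the present change only loosely: it shows that adding or removing a methoxy at one site leaves the number essentially unchanged, but it does not test the methoxy on the 4-methoxyphenyl group. Going by the values given here, no measured pair carries the 4-methoxyphenyl to phenyl change itself.

Among the compounds with values here, with one uninformative step as the only guide, no movement beyond the scatter is expected, and the step of a 1.2-fold higher number from compound 2 to compound 3 (0.08 log units; within the scatter) is estimated as small. Compound 3 is expected at about 380 nM, within 150 nM to 950 nM.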

Compound 3, concentration for 50% growth inhibition: 3100 nM
Estimate against measurement, compound 3: 8.2-fold (0.91 log units) below; the measured number lies above the stated range.
By their numbers in this assay, from the lowest: compounds 2 and 1 (each within the scatter of the next); then compound 3.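

In this assay, for the compounds shown here, the change from 4-methoxyphenyl to phenyl is the first to move the number beyond the scatter: a 9.7-fold higher number from compound 2 to compound 3 (0.99 log units; beyond the scatter). The methoxy on an aromatic carbon, para to a large group, is therefore not interchangeable with the methoxy elsewhere on the shared core, where a 1.1-fold lower number from compound 1 to compound 2 (0.03 log units; within the scatter) lies within the scatter, so the earlier finding of little change does not extend to every methoxy in the series. Nothing at hand explains the loss of growth inhibition, and the size of the step stands here as an observation only.

The compounds shown leave open whether a hydroxy, an ethoxy or an amine at this same place would keep the number close to that of compound 2, or whether only methoxy does so. They also leave open whether the 4-methoxyphenyl to phenyl change has a step of similar size on the core of compound 1, which lacks the second methoxy, since the present step is read on a single pair.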